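The source may report more compounds than this note shows. Statements on the series, on what has been measured and on what is new or still open speak of the compounds shown alone.

Working notes on the series. Compound 1, `Fc1cccc(Nc2nc(-c3cccc(F)c3)nc3ccc(F)cc23)c1`, has been measured in a functional assay on HT29-AK cells (Homo sapiens) for cytotoxicity, read by MTT assay, with a stated time of 48 h; on this read-out lower numbers stand for stronger inhibition and higher numbers for weaker inhibition. In this assay compound 1 returns > 50000 nM, which is a limit of the assay and not a number. Compound 2, `Fc1cccc(-c2nc(Nc3ccccc3Cl)c3cc(F)ccc3n2)c1`, differs from compound 1 by 2-chlorophenyl in place of 3-fluorophenyl on a nitrogen on an aromatic ring. In this assay compound 2 returns > 50000 nM, again a limit. Compound 3, `Nc1ccccc1Nc1nc(-c2cccc(F)c2)nc2ccc(F)cc12`, carries 2-aminophenyl on that nitrogen. In this assay compound 3 returns > 50000 nM, a limit as well. Within the data shown here, the steps among them are a step that the two limits leave unreadable from compound 1 to compound 2, a step that the two limits leave unreadable from compound 1 to compound 3 and a step that the two limits leave unreadable from compound 2 to compound 3; the only evidence is the limit of > 50000 nM in this assay, at which 3 of the 3 values shown sit, so no size can be read from any of them.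

Compound 4, `Cc1ccccc1Nc1nc(-c2cccc(F)c2)nc2ccc(F)cc12`, is not yet measured. From compound 1 it differs as follows: 2-methylphenyl in place of 3-fluorophenyl on a nitrogen on an aromatic ring. Among the measured compounds shown here, the measured steps that exchange the group on that nitrogen bear on this change, but none of them yields a readable size, and no measured compound gives a number short of the limit. The expectation for compound 4 is therefore a value near that limit, with a step from compound 1 estimated as a number no higher from compound 1 to compound 4 (the limit leaves the size open). Compound 4 is expected to show 50000 nM in this assay, within an estimated range of 15000 nM to 150000 nM.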

Compound 4, half-maximal inhibitory concentration: > 50000 nM
Compound 4: no number, only a limit; the forecaster's own chance of this, stated with the estimate: 80%; the middle value lies on the limit itself.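

In this assay compound 4 returns > 50000 nM as a limit and not a number. Among these compounds, no step among compound 1, compound 2, compound 3 and compound 4 can be read, as all rest on one shared limit: the limit of > 50000 nM in this assay, at which 4 of the 4 values shown sit. The compounds shown leave open the size of every step among them, and whether any group on that nitrogen gives a number short of the limit.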